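A few compounds are considered here, and "the series" means these few. Any claim that something is new, unique, unknown or untested is made for them only; others in the source may bear on it.

Of the compounds shown here, three have so far been measured in an assay on ileum with muscarinic acetylcholine receptor M3 (Cavia porcellus) as the target; a higher number here means a weaker inhibitor, a lower number a stronger inhibitor. Compound 1 `Cc1nccn1CCCC(C(N)=O)(c1ccccc1)c1ccccc1` gives 1.14 nM, compound 2 `Cc1nccn1CCCCC(C(N)=O)(c1ccccc1)c1ccccc1` gives 43.7 nM, and compound 3 `Cc1nccn1CCC(O)(c1ccccc1)c1ccccc1` gives 16.7 nM. Compound 3 therefore stands second highest of the three numbers: compound 2 lies above it, beyond the scatter, and compound 1 lies well below it, also beyond the scatter. Only one pair of these compounds differs in a single place, and that step is a 38-fold higher number from compound 1 to compound 2 (1.58 log units; beyond the scatter), a large loss for one added chain carbon.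

Compound 4 `Cc1nccn1CCC(CO)(c1ccccc1)c1ccccc1` arises from compound 3 by hydroxymethyl in place of hydroxy on a saturated chain carbon bound to two aromatic carbons and a saturated chain carbon. Among the compounds with values here, no measured step tests this exact change. Within the data shown here, the one step that exists, from compound 1 to compound 2, also inserts a single saturated carbon into the molecule, and it was large; it is the only guide available, and it points toward a higher number for compound 4. Because that step was a 38-fold higher number from compound 1 to compound 2 (1.58 log units; beyond the scatter), an increase beyond the scatter is expected for compound 4, though a more moderate one is assumed here given that the change is not the same one. Compound 4 is expected to give 80 nM, with a range from 20 nM to 300 nM. The expected step is thus a 4.8-fold higher number from compound 3 to compound 4 (0.68 log units; beyond the scatter).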

Compound 4, antagonist equilibrium constant: 25.4 nM
Estimate against measurement, compound 4: 3.1-fold (0.50 log units) above; the measured number falls inside the stated range.
By their numbers in this assay, from the lowest: compound 1; then compounds 3, 4 and 2 (each within the scatter of the next, the first and the last beyond it).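

In this assay, hydroxymethyl in place of hydroxy on a saturated chain carbon bound to two aromatic carbons and a saturated chain carbon gives a 1.5-fold higher number from compound 3 to compound 4 (0.18 log units; within the scatter), so at this place the two groups cannot be told apart. Within the data shown here, until now the only single-place change on record was a 38-fold higher number from compound 1 to compound 2 (1.58 log units; beyond the scatter), which showed that one more carbon can matter greatly in these compounds; the new step shows that, at this other place and with the counts of hydrogen-bond donors and acceptors unchanged, one more carbon need not matter at all. Nothing at hand explains why these two steps differ in size.

On these data alone, it remains open whether this place accepts groups other than these two, such as an amine, a methoxy group, a carboxylic acid or a longer chain like hydroxyethyl, or whether the tolerance seen in compound 4 ends with hydroxymethyl. Also open, as far as these compounds go, is whether one more carbon in the chain bearing 2-methyl-1H-imidazol-1-yl would have as large an effect on compound 3 as it had on compound 1.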